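A few compounds are considered here, and "the series" means these few. Any claim that something is new, unique, unknown or untested is made for them only; others in the source may bear on it.

Measured so far in a functional assay on CHO cells for antagonist activity at adenosine receptor A2b (Homo sapiens), read by cAMP accumulation; on this read-out higher numbers stand for weaker inhibition and lower numbers for stronger inhibition:
Compound 1 `CCOc1cccc2cc(-c3ccccc3)c(=O)oc12` gives > 30000 nM, which is a limit of the assay rather than a number.
Compound 2 `CCOc1cccc2cc(-c3ccc(OC)cc3)c(=O)oc12` gives > 30000 nM, again only a limit.
Compound 3 `CCOc1cccc2cc(-c3ccc([N+](=O)[O-])cc3)c(=O)oc12` gives > 30000 nM, also a limit.

Compound 3 therefore stands at the edge of what this assay can report, and it shares that position with the other two compounds, since (the limit of > 30000 nM in this assay, at which 3 of the 3 values shown sit). The three measured steps, a step that the two limits leave unreadable from compound 1 to compound 2, a step that the two limits leave unreadable from compound 1 to compound 3 and a step that the two limits leave unreadable from compound 2 to compound 3, all change the group on the pendant phenyl ring, and none of them can be read in size, because both ends sit at the limit.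

Compound 4 `Cc1cccc2cc(-c3ccc([N+](=O)[O-])cc3)c(=O)oc12` differs from compound 3 at another place: methyl in place of ethoxy on an aromatic carbon. For the measured compounds named here, no measured step touches this position, so nothing in the data speaks for or against a change in this assay. The step from compound 3 to compound 4 is expected to be a number no higher from compound 3 to compound 4 (the limit leaves the size open), that is, no movement that could be read. Compound 4 is therefore estimated to give 30000 nM in this assay, within a range from 8000 nM to 100000 nM, and most likely to be reported only as a limit again.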

Compound 4, half-maximal inhibitory concentration: > 30000 nM
Compound 4 was reported as a limit (the forecaster's own chance of this, stated with the estimate: 85%); the middle value sits exactly at the limit.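

Compound 3 and compound 4 both give only a limit, so the step between them cannot be read in size in this assay: the limit of > 30000 nM in this assay, at which 4 of the 4 values shown sit. The compounds shown leave open whether any group at the places changed here would give a readable number in this assay.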